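The source may hold more compounds than are shown below. What is called first, only, known or untested is meant among the compounds shown, and "the series" means these compounds.

Three compounds sharing one core were tested in a functional assay on DU-145 cells (Homo sapiens) for cytotoxicity, read by sulforhodamine B assay, with a stated time of 48 h; on this read-out lower numbers stand for higher toxicity in this test and higher numbers for lower toxicity in this test. Compound 1 `COc1ccc(CN2CCN(c3nc(Nc4ccc(C#N)c(C(F)(F)F)c4)nc(Oc4ccnc5ccccc45)n3)CC2)c(OC)c1OC` reaches only the limit of the test, > 100000 nM. Compound 2 `N#Cc1ccc(Nc2nc(Oc3ccnc4ccccc34)nc(N3CCN(c4ccccc4)CC3)n2)cc1C(F)(F)F` likewise gives only a limit, > 100000 nM. Compound 3 `N#Cc1ccc(Nc2nc(Oc3ccnc4ccccc34)nc(N3CCN(C(c4ccccc4)c4ccc(Cl)cc4)CC3)n2)cc1C(F)(F)F` also stops at a limit, > 100000 nM. No number is therefore known for compound 2; it stands at the limit of > 100000 nM in this assay, at which 3 of the 3 values shown sit. Compound 4 `COc1ccc(N2CCN(c3nc(Nc4ccc(C#N)c(C(F)(F)F)c4)nc(Oc4ccnc5ccccc45)n3)CC2)cc1` differs from compound 2 by methoxy in place of hydrogen on an aromatic carbon. Among the measured compounds shown here, because every measured compound sits at the limit of > 100000 nM in this assay, at which 3 of the 3 values shown sit, no step between measured compounds can be read, and the change from hydrogen to methoxy is expected to bring none beyond the scatter, a step that the limit leaves unreadable from compound 2 to compound 4. Compound 4 is accordingly estimated at 150000 nM, between 50000 nM and 500000 nM, most likely reported once more as a limit only.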

Compound 4, concentration lethal to 50% of the cells: > 100000 nM
Compound 4: no number, only a limit; the forecaster's own chance of this, stated with the estimate: 85%; the middle value lies beyond the limit too.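

No new step can be read, as compound 2 and compound 4 both stop at a limit: the limit of > 100000 nM in this assay, at which 4 of the 4 values shown sit. The compounds shown leave open whether methoxy in place of hydrogen, or any other change on the shared core, makes any difference in this assay.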